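A few compounds are considered here, and "the series" means these few. Any claim that something is new, unique, unknown or untested is made for them only; others in the source may bear on it.

The measured compounds:
compound 1, `COc1ccc2c(=O)c(/C=C/C(=O)Nc3cccc(Cl)c3)coc2c1`: > 100000 nM
compound 2, `COc1ccc2c(=O)c(/C=C/C(=O)Nc3ccc(Cl)cc3)coc2c1`: > 100000 nM
compound 3, `Cc1ccccc1NC(=O)/C=C/c1coc2cc(O)ccc2c1=O`: 9320 nM

Compound 1, whose structure is `COc1ccc2c(=O)c(/C=C/C(=O)Nc3cccc(Cl)c3)coc2c1`, gives in a functional assay (QGY7701 cells, Homo sapiens) for inhibition, read by MTT assay, with a stated time of 48 h (a lower number here means a stronger inhibitor, a higher number a weaker inhibitor), the value > 100000 nM, which is a limit of the assay and not a number. Compound 2, `COc1ccc2c(=O)c(/C=C/C(=O)Nc3ccc(Cl)cc3)coc2c1`, likewise gives only a limit in this assay, namely > 100000 nM. Going by the values given here, the single step that joins two measured compounds, a step that the two limits leave unreadable from compound 1 to compound 2, is therefore unreadable, since the limit of > 100000 nM in this assay, at which 2 of the 3 values shown sit, holds both of its ends. Among the compounds with values here, compound 3, `Cc1ccccc1NC(=O)/C=C/c1coc2cc(O)ccc2c1=O`, stands apart: in this assay compound 3 gives 9320 nM, an actual number, but no single-change step links compound 3 to compound 1, so its value shows only that the shared core can reach measurable inhibition.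

The compound still to be measured is compound 4, `COc1ccc(CNC(=O)/C=C/c2coc3cc(OC)ccc3c2=O)cc1`. It differs from compound 1 in that (4-methoxybenzyl in place of 3-chlorophenyl on an amide-type nitrogen). Within the data shown here, no measured step bears on a change of this kind; the one step at hand, a step that the two limits leave unreadable from compound 1 to compound 2, tells nothing of size or direction. Because compound 1 sits at > 100000 nM, a limit, any expectation for compound 4 is loose. The step of an at least 1.6-fold lower number from compound 1 to compound 4 (0.22 log units; that floor lies within the scatter) is expected to be small, with compound 4 likely staying near the limit. Compound 4 is estimated at 60000 nM, within 10000 nM to 400000 nM.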

Compound 4, half-maximal inhibitory concentration: 15700 nM
Compound 4: middle estimate off by 3.8-fold (0.58 log units), on the high side; measured number inside the range.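

The position on the amide-type nitrogen now gives readable steps in this assay: 4-methoxybenzyl in place of 3-chlorophenyl gives an at least 6.3-fold lower number from compound 1 to compound 4 (0.80 log units; beyond the scatter), and 4-methoxybenzyl in place of 4-chlorophenyl gives an at least 6.3-fold lower number from compound 2 to compound 4 (0.80 log units; beyond the scatter). The group on this nitrogen can therefore move the number by more than the usual scatter on this core, something the two chlorophenyl compounds could not show, as the step between them cannot be read. Both new steps start from a limit and not a number, so each gives a floor and not a size: the limit of > 100000 nM in this assay, at which 2 of the 4 values shown sit.

The change from either chlorophenyl group to 4-methoxybenzyl alters both the substituent on the ring and the way the ring is joined to the nitrogen, and the compounds shown do not separate the two, so it remains open whether a plain benzyl, a 4-chlorobenzyl or a 4-methoxyphenyl group would give a similar number. Also open, going by these compounds, is how a longer chain such as phenethyl on the same nitrogen would read.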